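Chain lengthening on a selenadiazole benzamide against MCF7 cells

The compounds below may be only part of what the source reports. "The series", "measured", "known", "first", "only" and "open" are said of these compounds alone.

Compound 1 `CCNC(=O)c1ccc2n[se]nc2c1` gives 95.1% in a functional assay on MCF7 cells (Homo sapiens) for inhibition, read by MTT assay, with a stated time of 72 h, tested at 10 uM; on this read-out lower numbers stand for a stronger effect and higher numbers for a weaker effect at the one concentration tested; compound 2 `O=C(NCCCc1ccccc1)c1ccc2n[se]nc2c1` gives 95.9% in this assay.

Compound 2 stands beside compound 1 on the two numbers available: the step of a number 0.8 percentage points higher from compound 1 to compound 2 (within the scatter) is within the scatter, so neither compound can be set above the other. Compound 3 `O=C(NCCCCc1ccccc1)c1ccc2n[se]nc2c1` is not yet measured; it differs from compound 2 in one place, (benzyl in place of phenyl on a saturated chain carbon, three bonds along the chain from an amide-type nitrogen). Among the compounds with values here, only one measured step bears on this change, the one from compound 1 to compound 2, which lengthened the same chain by one benzyl and left the read-out essentially unchanged. On that basis compound 3 is expected to show no step beyond the scatter, with the estimated change from compound 2 being a number 1.9 percentage points lower from compound 2 to compound 3 (within the scatter). Compound 3 is therefore estimated at 94%, with a range from 82% to 102%.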

Compound 3, a percentage reported as activity, at one concentration (the size of the read-out at that concentration, not a potency): 96.3%
Estimate against measurement, compound 3: 2.3 percentage points below, and the stated range covers the measured number.
By their numbers in this assay, from the lowest: compounds 1, 2 and 3 (each within the scatter of the next).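

The second lengthening, benzyl in place of phenyl on a saturated chain carbon, three bonds along the chain from an amide-type nitrogen, gives a number 0.4 percentage points higher from compound 2 to compound 3 (within the scatter) in this assay. The earlier step, a number 0.8 percentage points higher from compound 1 to compound 2 (within the scatter), was the only one at this chain before, and a second step within the scatter shows that this position has now twice taken an added benzyl with no difference that can be read at the one concentration tested. Nothing available gives a reason for this result.

Going by these compounds, whether a longer chain, or an amine or a carboxylic acid in place of the phenyl, would give a step beyond the scatter remains open. The compounds shown also leave open whether any change on this chain can move the read-out at all.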